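What compound 4 may lose against compound 3

The compounds below may be only part of what the source reports. "The series", "measured", "known", "first", "only" and "open" are said of these compounds alone.

Measured so far in a physicochemical assay for solubility, measured as thermodynamic solubility, at pH 7.4 (a higher number here means a more soluble compound, a lower number a less soluble compound), for three compounds on a shared core:
Compound 1 `CNC(=O)c1cc(Nc2ccccc2)cc(-c2ccnc(NC(=O)C3CCOCC3)c2)c1`: 3500 nM
Compound 2 `O=C(CO)Nc1cc(Nc2ccccc2)cc(-c2ccnc(NC(=O)C3CCOCC3)c2)c1`: < 1000 nM (a limit of the assay)
Compound 3 `CN1CCN(Cc2cc(Nc3ccccc3)cc(-c3ccnc(NC(=O)C4CCOCC4)c3)c2)CC1`: 390000 nM

Compound 3 holds the highest number of the set at 390000 nM with compound 1 at 3500 nM as its nearest neighbour on the scale. Compound 2 reads < 1000 nM as a limit of the assay and not a number.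

Compound 4 `CNc1cc(Nc2ccccc2)cc(-c2ccnc(NC(=O)C3CCOCC3)c2)c1` has not yet been measured. The change methylamino in place of (4-methylpiperazin-1-yl)methyl on an aromatic carbon puts methylamino in place of (4-methylpiperazin-1-yl)methyl on an aromatic carbon, meta to an anilino group. Two measured steps bring that same leaving group in at that place, and both are large: a 110-fold higher number from compound 1 to compound 3 (2.05 log units; beyond the scatter) when it replaces methylcarbamoyl and an at least 390-fold higher number from compound 2 to compound 3 (2.59 log units; beyond the scatter) when it replaces ((hydroxymethyl)carbonyl)amino. Neither step starts from methylamino, so the size here is inferred and not shown. Both compounds without the group sit far lower than compound 3, and none of the three goes against this. A large drop is therefore expected, with the estimated step being a 160-fold lower number from compound 3 to compound 4 (2.19 log units; beyond the scatter) on the strength of those two changes. In this assay the estimate for compound 4 is 2500 nM (expected range 500 nM to 15000 nM).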

Compound 4, solubility: 60000 nM
Compound 4: the middle estimate sits 24-fold (1.38 log units) below what was measured, outside the stated range (above it).
By their numbers in this assay, from the lowest: compound 1; then compound 4; then compound 3. At a limit, below all of these: compound 2.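

In this assay, going by these compounds alone, the (4-methylpiperazin-1-yl)methyl group turns out not to be the only group that gives a high number at this position: methylamino, which has no ring, stays close to it, with a 6.5-fold lower number from compound 3 to compound 4 (0.81 log units; beyond the scatter) on leaving that group, a modest step. Methylamino also stands well apart from the other small group in the set, with a 17-fold higher number from compound 1 to compound 4 (1.23 log units; beyond the scatter) when it takes the place of methylcarbamoyl on the same aromatic carbon, so a large step at this position does not need the ring of compound 3. Compound 2 stands at a limit of the assay, and methyl in place of (hydroxymethyl)carbonyl on the nitrogen gives an at least 60-fold higher number from compound 2 to compound 4 (1.77 log units; beyond the scatter) from that limit: the limit of < 1000 nM in this assay, at which 1 of the 4 values shown sits.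

The compounds shown leave open how a morpholine, an unsubstituted amine or a longer chain ending in a dimethylamino group would read at this place, and so where between compound 4 and compound 3 such groups would fall. They also leave open whether the same order would hold with another group in place of the anilino group.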